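A few compounds are considered here, and "the series" means these few. Any claim that something is new, unique, unknown or untested is made for them only; others in the source may bear on it.

Of the compounds shown here, two sharing one core have been tested in a functional assay on HeLa cells (Homo sapiens) for cytotoxicity, read by neutral red uptake, with a stated time of 3 days; on this read-out lower numbers stand for stronger inhibition and higher numbers for weaker inhibition. Compound 1 `CCc1c(F)c(N)c2c(=O)cc(-c3ccc(N)c(F)c3)oc2c1F` gives only a limit there, > 100000 nM. Compound 2 `Nc1ccc(-c2cc(=O)c3c(N)c(F)c(Cl)c(F)c3o2)cc1F` likewise gives only a limit, > 100000 nM. For the measured compounds named here, the single step between them, a step that the two limits leave unreadable from compound 1 to compound 2, cannot be sized because of the limit of > 100000 nM in this assay, at which 2 of the 2 values shown sit. Compound 3 `CCCCCC(=O)OCc1c(F)c(N)c2c(=O)cc(-c3ccc(N)c(F)c3)oc2c1F` is the next compound to be measured in this assay. It differs from compound 2 in one place: ((pentylcarbonyl)oxy)methyl in place of chloro on an aromatic carbon. Going by the values given here, no measured step bears usefully on this change; the one available is unreadable, and both measured values stand at the same limit. Compound 3 is therefore expected to remain at that limit, the step that the limit leaves unreadable from compound 2 to compound 3 being an estimate of no change beyond the scatter. The estimated value for compound 3 is 150000 nM, in a range from 50000 nM to 500000 nM.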

Compound 3, half-maximal inhibitory concentration: 34000 nM
Estimate against measurement, compound 3: 4.4-fold (0.64 log units) above, and the stated range ends above it.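

In this assay, for the compounds shown here, this position, on an aromatic carbon ortho to two fluoro groups, can change the read-out: with ((pentylcarbonyl)oxy)methyl there, compound 3 is the first compound to give a measured number rather than a limit. Putting this group in place of chloro gives an at least 2.9-fold lower number from compound 2 to compound 3 (0.46 log units; beyond the scatter), and adding the (pentylcarbonyl)oxy group to the chain in place of its methyl gives an at least 2.9-fold lower number from compound 1 to compound 3 (0.46 log units; beyond the scatter). Both steps are only minimum sizes because the starting compound of each stands at a limit: the limit of > 100000 nM in this assay, at which 2 of the 3 values shown sit.

The compounds shown do not tell whether the lower number depends on the whole ester or only on part of it. On these data alone, how a hydroxymethyl group, an acetoxymethyl group or a longer ester chain would read at this position remains open.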